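The source may hold more compounds than are shown below. What is called first, only, known or untested is meant among the compounds shown, and "the series" means these compounds.

Series on the shared core of compound 1 `COc1cc(/C=C/C(=O)c2cccc(N)c2)ccc1O`, which in a functional assay on U-87MG ATCC cells (Homo sapiens) for inhibition (on this read-out lower numbers stand for stronger inhibition and higher numbers for weaker inhibition), gives 7.71 ug/mL. Compound 2 `COc1cc(/C=C/C(=O)c2cccc(NC(=O)C(C)C)c2)ccc1O` gives 8.31 ug/mL, and compound 3 `COc1cc(/C=C/C(=O)c2cccc(NC(=O)c3ccccc3)c2)ccc1O` gives 8.82 ug/mL; all three values sit within the scatter of one another, so compound 2 is neither set apart from compound 3 nor from compound 1 on these numbers. Compound 4 `COc1cc(/C=C/C(=O)c2cccc(NC(=O)c3ccc(Cl)cc3)c2)ccc1O` carries the change (4-chlorophenyl in place of isopropyl on a carbonyl carbon). Among the compounds with values here, the steps that bear on it are a 1.1-fold higher number from compound 1 to compound 2 (0.03 log units; within the scatter), a 1.1-fold higher number from compound 1 to compound 3 (0.06 log units; within the scatter) and, closest in kind, a 1.1-fold higher number from compound 2 to compound 3 (0.03 log units; within the scatter); none left the scatter. For compound 4 a step of a 1.1-fold higher number from compound 2 to compound 4 (0.03 log units; within the scatter) is therefore expected, none beyond the scatter. Compound 4 is estimated at 9 ug/mL, in the range 5.5 ug/mL to 15 ug/mL.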

Compound 4, half-maximal inhibitory concentration: > 50 ug/mL
Compound 4: only a limit was reported (the forecaster's own chance of this, stated with the estimate: 5%); at least 5.5-fold (0.74 log units) between middle value and limit.
By their numbers in this assay, from the lowest: compounds 1, 2 and 3 (each within the scatter of the next). At a limit, above all of these: compound 4.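

In this assay compound 4 is reported only as a limit, > 50 ug/mL. Chloro in place of hydrogen on an aromatic carbon gives an at least 5.6-fold higher number from compound 3 to compound 4 (0.75 log units; beyond the scatter), alongside an at least 6.0-fold higher number from compound 2 to compound 4 (0.77 log units; beyond the scatter) and an at least 6.4-fold higher number from compound 1 to compound 4 (0.81 log units; beyond the scatter), so the series is not insensitive to every change at this nitrogen, although hydrogen, isopropylcarbonyl and benzoyl stayed within the scatter. Each of these steps is bounded by a limit, so its full size stays unknown: the limit of > 50 ug/mL in this assay, at which 1 of the 4 values shown sits.

On these data alone, whether this step is specific to chloro stays open. Fluoro, methoxy or an amine in place of the chloro would address that.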